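Nitro in Place of Hydrogen on the Shared Core

The source may hold more compounds than are shown below. What is called first, only, known or untested is meant among the compounds shown, and "the series" means these compounds.

Among the compounds with values here, compound 1 `O=C(N/N=C/c1ccncc1)c1cc2ccccc2oc1=O` is one of three compounds measured in a functional assay on HepG2 cells (Homo sapiens) for antiproliferative activity, read by fluorescence and resazurin assay, with a stated time of 48 h (a lower number here means a stronger inhibitor, a higher number a weaker inhibitor), where compound 1 gives 17200 nM. Compound 2 `CCOc1ccc(NC(=O)c2cc3ccc(O)cc3oc2=O)cc1` gives 17300 nM in the same assay, and compound 3 `O=C(N/N=C/c1cccnc1)c1cc2ccccc2oc1=O` gives 15900 nM. Compound 1 stands second highest of the three numbers, yet all three lie within the scatter of one another, so no order among them can be read. Within the data shown here, the only step between compounds differing in one place is a 1.1-fold lower number from compound 1 to compound 3 (0.03 log units; within the scatter), and it does not touch the part of compound 1 that changes next.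

Compound 4 `O=C(N/N=C/c1ccncc1)c1cc2cc([N+](=O)[O-])ccc2oc1=O` differs from compound 1 in this way: nitro in place of hydrogen on an aromatic carbon. No measured pair shows a nitro entering in place of hydrogen anywhere, so no shown step bears on this change. The account therefore expects no step beyond the scatter in this assay, in neither direction, and expects a 1.0-fold lower number from compound 1 to compound 4 (0.01 log units; within the scatter). Compound 4 is thus estimated at 17000 nM, within a range from 7000 nM to 40000 nM.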

Compound 4, half-maximal inhibitory concentration: 15800 nM
Beside the measured number, compound 4's estimate is 1.1-fold (0.03 log units) above it, within the range that was stated.
By their numbers in this assay, from the lowest: compounds 4, 3, 1 and 2 (each within the scatter of the next).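

In this assay, nitro in place of hydrogen on an aromatic carbon of the shared core gives a 1.1-fold lower number from compound 1 to compound 4 (0.04 log units; within the scatter) and so leaves no readable difference at this position, which is meta to a fused ring and para to a fused ring. Within the data shown here, the only earlier step exchanged pyridin-4-yl for pyridin-3-yl, so this is the first reading of a change on the core of compound 1 itself, and this position accepts nitro with no shift beyond the scatter. Nothing measured on these compounds offers an explanation for this result.

As far as these compounds go, whether an amine or a carboxylic acid in place of hydrogen on this same carbon would also stay within the scatter remains open. So does whether nitro on another aromatic carbon of the shared core would do so, since a single step at one position gives no trend.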